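This account rests on a few compounds, and the source may have more. Where it says the series, first, only, none or still open, it means among the compounds named here.

Measured in an assay on isolated protein for inhibition of phosphodiesterase 1 (Bos taurus), read by cGMP accumulation, in the presence of a further agent that is not named here; on this read-out lower numbers stand for stronger inhibition and higher numbers for weaker inhibition:
Compound 1 `C=CCOc1cc(C2CNC(=O)C2)ccc1OC`: > 1000000 nM, a limit of the assay.
Compound 2 `CCCCOc1cc(C2CNC(=O)C2)ccc1OC`: > 1000000 nM, a limit of the assay.
Compound 3 `COc1ccc(C2CNC(=O)C2)cc1OCC(C)C`: > 1000000 nM, a limit of the assay.

Compound 3 thus stands at the assay limit, where all three measured values sit, as the limit of > 1000000 nM in this assay, at which 3 of the 3 values shown sit, records. Compound 4 `C=C(C)COc1cc(C2CNC(=O)C2)ccc1OC` differs from compound 3 by 1-methylethenyl in place of isopropyl on a saturated chain carbon bound to an oxygen on an aromatic ring. Among the measured compounds shown here, the steps that bear on this, a step that the two limits leave unreadable from compound 1 to compound 3 and a step that the two limits leave unreadable from compound 2 to compound 3, together with a step that the two limits leave unreadable from compound 1 to compound 2, are all unreadable, since each joins two limits. Compound 1, which bears a vinyl at the same place, also sits at the limit, so a double bond in this chain has not yet brought inhibition into the measurable range. Compound 4 is therefore expected to remain at the limit, the step of a number no higher from compound 3 to compound 4 (the limit leaves the size open) meaning no readable change. Compound 4 is estimated at 1000000 nM in this assay, within 300000 nM to 3000000 nM.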

Compound 4, half-maximal inhibitory concentration: > 1000000 nM
Compound 4 gave a limit, no number (the forecaster's own chance of this, stated with the estimate: 90%); the middle value lies on the limit itself.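

No step among compound 1, compound 2, compound 3 and compound 4 can be read, because each joins two limits: the limit of > 1000000 nM in this assay, at which 4 of the 4 values shown sit.

As far as these compounds go, how far each compound lies past that limit, and whether any change to this chain gives a measurable inhibition, stays open.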